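The source may hold more compounds than are shown below. What is called first, only, known or untested is meant among the compounds shown, and "the series" means these compounds.

The compounds measured so far:
- compound 1, `FC(F)(F)c1ccc(COc2cccc(Nc3ncnc4cc5c(cc34)OCCOCCO5)c2)cc1`: > 100000 nM
- compound 2, `FC(F)(F)c1ccc(COc2cccc(Nc3ncnc4cc5c(cc34)OCCOCCOCCO5)c2)cc1`: 17600 nM
- compound 3, `c1ccc(COc2cccc(Nc3ncnc4cc5c(cc34)OCCOCCOCCO5)c2)cc1`: > 100000 nM

In a functional assay on MCF7 cells (Homo sapiens) for antiproliferative activity, read by MTT assay, with a stated time of 72 h (a lower number here means a stronger inhibitor, a higher number a weaker inhibitor), compound 1 gives > 100000 nM, which is a limit of the assay rather than a number. Compound 2, with the longer chain on the shared core, gives 17600 nM. Compound 3 gives > 100000 nM, again a limit of the assay. Among the measured compounds shown here, the step of an at least 5.6-fold higher number from compound 2 to compound 3 (0.75 log units; beyond the scatter) is therefore the only measured guide to the change now in question.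

Compound 4, `c1ccc(COc2cccc(Nc3ncnc4cc5c(cc34)OCCOCCO5)c2)cc1`, differs from compound 1 in one place: hydrogen in place of trifluoromethyl on an aromatic carbon. This is the same exchange that was measured from compound 2 to compound 3, where it gave a weaker inhibitor. Compound 1 already sits at the limit of > 100000 nM in this assay, at which 2 of the 3 values shown sit. Applying a change that elsewhere weakened the inhibitor to a compound that is already at that limit leaves no room for an upward step to appear in the numbers. Compound 4 is therefore expected to give 300000 nM in this assay, with a range from 100000 nM to 1000000 nM. The step from compound 1 is expected to be a step that the limit leaves unreadable from compound 1 to compound 4, most likely reported only as a limit.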

Compound 4, half-maximal inhibitory concentration: 40900 nM
For compound 4 the middle estimate is 7.3-fold (0.87 log units) above the measured one, and the stated range ends above it.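

On the core of compound 1, replacing the trifluoromethyl of the 4-(trifluoromethyl)benzyl group with hydrogen gives a stronger inhibitor in this assay, with an at least 2.4-fold lower number from compound 1 to compound 4 (0.38 log units; beyond the scatter). The earlier compounds shown here showed this exchange only as a loss, but on these two cores it runs in opposite directions, so the result on one core does not carry over to the other: the same change on two cores in this assay, an at least 5.6-fold higher number (0.75 log units; beyond the scatter) from compound 2 to compound 3 and an at least 2.4-fold lower number (0.38 log units; beyond the scatter) from compound 1 to compound 4, at least 13-fold (1.14 log units) apart, beyond the scatter of two such steps. Compound 1 gives > 100000 nM, which is a limit of the assay and leaves the full size of its step unknown: the limit of > 100000 nM in this assay, at which 2 of the 4 values shown sit.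

As far as these compounds go, what a chlorine, a methoxy group or a nitrile on the same aromatic carbon would do on either core remains open. From the compounds shown here alone, it is also open whether the opposite directions of this exchange would hold on a core with a different chain.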